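A few compounds are considered here, and "the series" means these few. Any claim that something is new, unique, unknown or untested is made for them only; others in the source may bear on it.

Notes on the series. Compound 1 `CN(C)c1ccc(/C=C2/C(=O)NN(c3ccc(Br)cc3)C2=O)cc1` and compound 2 `CN(C)c1ccc([N+](=O)[O-])cc1/C=C1/C(=O)NN(c2cccc(Cl)c2)C1=O` share the same core and differ from each other at two places. In a toxicity assay on HEK293 cells (Homo sapiens) for cytotoxicity (on this read-out lower numbers stand for stronger inhibition and higher numbers for weaker inhibition), compound 1 gives > 100000 nM, which is a limit of the assay and not a number. In this assay compound 2 likewise gives > 100000 nM, again a limit rather than a number. Compound 2 thus stands at the limit of this assay alongside compound 1, as the limit of > 100000 nM in this assay, at which 2 of the 2 values shown sit, shows, and no order between the two can be read from these values. Compound 3 `CN(C)c1ccc([N+](=O)[O-])cc1/C=C1/C(=O)NN(c2ccccc2)C1=O` has not yet been measured. It differs from compound 2 by hydrogen in place of chloro on an aromatic carbon. With both values shown sitting at the limit, no step beyond the usual scatter is expected in this assay in either direction. The expected step is a step that the limit leaves unreadable from compound 2 to compound 3. Compound 3 is estimated to give 150000 nM, within 50000 nM to 500000 nM, and is most likely to be reported again as a limit.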

Compound 3, half-maximal inhibitory concentration: > 100000 nM
Compound 3 ended at the assay's limit; the forecaster's own chance of this, stated with the estimate: 85%; the middle value is on the limit's open side.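

Compound 2 and compound 3 both sit at the limit of this assay, so no step can be read between them: the limit of > 100000 nM in this assay, at which 3 of the 3 values shown sit.

The compounds shown leave open how the change from 3-chlorophenyl to phenyl, or any other difference among them, acts on this read-out.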